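This account rests on a few compounds, and the source may have more. Where it says the series, first, only, none or still open, it means among the compounds named here.

Measured so far:
Compound 1, `Cn1c(-c2ccccc2Cl)cnc1NC(=O)c1ccc(F)cc1`, in a toxicity assay on THP-1 cells (Homo sapiens) for inhibition (on this read-out higher numbers stand for lower toxicity in this test and lower numbers for higher toxicity in this test), gives > 50000 nM, which is a limit of the test and not a number.
Compound 2, `Cc1ccccc1-c1cnc(NC(=O)c2ccc(F)cc2)n1C`, gives > 50000 nM, again a limit rather than a number.
Compound 3, `O=C(Nc1ncc(-c2ccccc2)o1)c1ccc(Cl)cc1`, gives 10000 nM.

Compound 1 and compound 2 differ by one change, (methyl in place of chloro on an aromatic carbon). The size of the step that the two limits leave unreadable from compound 1 to compound 2 cannot be read, since (the limit of > 50000 nM in this assay, at which 2 of the 3 values shown sit). Compound 4, `Cc1ccc(C(=O)Nc2ncc(-c3ccccc3)o2)cc1`, is not yet measured; it differs from compound 3 by methyl in place of chloro on an aromatic carbon, the same kind of change as between compound 1 and compound 2, but at a different place: there the group sits ortho to a large group, here para to a large group. The difference between the two cores is not broken down here. No readable step exists for this change, so the expectation rests on the value of compound 3, 10000 nM, and stays near it. The step from compound 3 to compound 4 is expected to be a 1.5-fold higher number from compound 3 to compound 4 (0.18 log units; within the scatter). Compound 4 is expected to give about 15000 nM, between 5000 nM and 50000 nM.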

Compound 4, half-maximal cytotoxic concentration: 26000 nM
Beside the measured number, compound 4's estimate is 1.7-fold (0.24 log units) below it; measured number inside the range.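

In this assay, methyl in place of chloro, para to a large group, gives a 2.6-fold higher number from compound 3 to compound 4 (0.41 log units; beyond the scatter), a modest step that points to lower toxicity in this test on this one core. Among these compounds, the same swap, ortho to a large group on the core of compound 1, cannot be read, because compound 1 and compound 2 both stand at a limit rather than a number: the limit of > 50000 nM in this assay, at which 2 of the 4 values shown sit. The change therefore has only one readable step, so nothing shows whether it carries from one core to the other.

On these data alone, it remains open how other groups in this place, such as an amine, a methoxy group or a carboxylic acid, would read. Also open, as far as these compounds go, is how the core of compound 1 would respond with its group para to a large group.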